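Fluorine Position on the Benzyl Group and Raji Cell Cytotoxicity

A few compounds are considered here, and "the series" means these few. Any claim that something is new, unique, unknown or untested is made for them only; others in the source may bear on it.

Three compounds share one core and differ only in where fluorine sits on the benzyl group. Compound 1 `O=C(O)CN1C(=O)/C(=C/c2nc3ccccc3n2Cc2ccccc2F)SC1=S` gives 1230 nM in a functional assay on Raji cells (Homo sapiens) for cytotoxicity, read by MTT assay, with a stated time of 48 h; on this read-out lower numbers stand for stronger inhibition and higher numbers for weaker inhibition. Compound 2 `O=C(O)CN1C(=O)/C(=C/c2nc3ccccc3n2Cc2ccc(F)cc2F)SC1=S` gives 8960 nM in this assay, and compound 3 `O=C(O)CN1C(=O)/C(=C/c2nc3ccccc3n2Cc2cccc(F)c2)SC1=S` gives 13300 nM in this assay. The change from compound 1 to compound 2, (fluoro in place of hydrogen on an aromatic carbon), made a 7.3-fold higher number from compound 1 to compound 2 (0.86 log units; beyond the scatter). Compound 1 and compound 3 differ by 3-fluorophenyl in place of 2-fluorophenyl on a saturated chain carbon bound to an aromatic nitrogen, which made an 11-fold higher number from compound 1 to compound 3 (1.03 log units; beyond the scatter). Between compound 2 and compound 3 there is a 1.5-fold higher number from compound 2 to compound 3 (0.17 log units; within the scatter).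

Compound 4 `O=C(O)CN1C(=O)/C(=C/c2nc3ccccc3n2Cc2ccc(F)c(F)c2)SC1=S` has not yet been measured. It differs from compound 3 by fluoro in place of hydrogen on an aromatic carbon. This is the same kind of change as from compound 1 to compound 2, but not the same: there the entering fluoro was meta to a fluoro group, here it is ortho to a fluoro group, while in both it is para to a large group. Because the earlier change gave a 7.3-fold higher number from compound 1 to compound 2 (0.86 log units; beyond the scatter), a weakening step is expected here, a 2.6-fold higher number from compound 3 to compound 4 (0.42 log units; beyond the scatter), though the different surroundings leave it uncertain. For compound 4 the expected value is 35000 nM, within 9000 nM to 130000 nM.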

Compound 4, half-maximal inhibitory concentration: 7250 nM
Estimate against measurement, compound 4: 4.8-fold (0.68 log units) above; the measured number lies below the stated range.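

In this assay, adding a fluoro group para to a large group did not give the same result on the two cores: the same change on two cores in this assay, a 7.3-fold higher number (0.86 log units; beyond the scatter) from compound 1 to compound 2 and a 1.8-fold lower number (0.26 log units; within the scatter) from compound 3 to compound 4, 13-fold (1.13 log units) apart, beyond the scatter of two such steps

The new step, a 1.8-fold lower number from compound 3 to compound 4 (0.26 log units; within the scatter), therefore cannot be read as a real change, and a 1.2-fold lower number from compound 2 to compound 4 (0.09 log units; within the scatter) likewise leaves those two compounds indistinguishable, while a 5.9-fold higher number from compound 1 to compound 4 (0.77 log units; beyond the scatter) is a difference beyond the scatter and leaves compound 1 with the lowest number of the four. This shows that, in these compounds, the step seen on compound 1 cannot be used to predict the step on compound 3, but one pair of steps does not explain why they differ or show how the same change would behave on any other core.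

As far as these compounds go, it remains open what a chloro or methoxy group would do in place of these fluoro groups. From the compounds shown here alone, it is also open how a benzyl group with no fluoro at all would compare with compound 1.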